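Chloro for Fluoro, Tried a Second Time

The source may hold more compounds than are shown below. What is called first, only, known or untested is meant among the compounds shown, and "the series" means these compounds.

In a functional assay on HT-1080 cells (Homo sapiens), read by transwell migration, with a stated time of 24 h, tested at 1 uM (on this read-out higher numbers stand for a weaker effect at the one concentration tested and lower numbers for a stronger effect), compound 1 `O=C(Oc1cccc(F)c1)c1cc2cc([N+](=O)[O-])ccc2oc1=O` gives 53.6%, compound 2 `O=C(Oc1cccc(Cl)c1)c1cc2cc([N+](=O)[O-])ccc2oc1=O` gives 65.8%, and compound 3 `NCc1ccc2oc(=O)c(C(=O)Oc3cccc(F)c3)cc2c1` gives 45.3%. The change chloro in place of fluoro on an aromatic carbon produced the step of a number 12.2 percentage points higher from compound 1 to compound 2 (beyond the scatter). The two cores differ by aminomethyl in place of nitro on an aromatic carbon, and that difference gave the step of a number 8.3 percentage points lower from compound 1 to compound 3 (within the scatter). Compound 4 `NCc1ccc2oc(=O)c(C(=O)Oc3cccc(Cl)c3)cc2c1` has not been measured; it differs from compound 3 by chloro in place of fluoro on an aromatic carbon, the same change as from compound 1 to compound 2, at a place described in the same words. Going by the values given here, because the one earlier example gave a number 12.2 percentage points higher from compound 1 to compound 2 (beyond the scatter), a step of similar size is expected here, and the estimated step is a number 11.7 percentage points higher from compound 3 to compound 4 (beyond the scatter), resting on that single precedent alone. Compound 4 is therefore expected to give 57% in this assay, with the likely range running from 44% to 70%.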

Compound 4, a percentage reported as activity, at one concentration (the size of the read-out at that concentration, not a potency): 86.6%
Compound 4: the middle estimate sits 29.6 percentage points below what was measured; the whole stated range lies below it.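

In this assay, chloro in place of fluoro gave a number 41.3 percentage points higher from compound 3 to compound 4 (beyond the scatter), so the number moved the same way on both cores but not by the same amount: the same change on two cores in this assay, a number 12.2 percentage points higher (beyond the scatter) from compound 1 to compound 2 and a number 41.3 percentage points higher (beyond the scatter) from compound 3 to compound 4, 29.1 percentage points apart, beyond the scatter of two such steps. Aminomethyl in place of nitro gave a number 20.8 percentage points higher from compound 2 to compound 4 (beyond the scatter), so the two changes do not simply add in these compounds: the same change on two cores in this assay, a number 8.3 percentage points lower (within the scatter) from compound 1 to compound 3 and a number 20.8 percentage points higher (beyond the scatter) from compound 2 to compound 4, 29.1 percentage points apart, beyond the scatter of two such steps. This shows that the step cannot be carried from one core to the other as a fixed amount, but two pairs do not show why the cores differ or how either would respond to other changes.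

The compounds shown leave open whether a bromo group in place of the chloro would give a step of either size. They also leave open whether a hydroxymethyl or an acetamide in place of the aminomethyl would show the same large step.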